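The compounds below may be only part of what the source reports. "The series", "measured", "known", "first", "only" and "open" are said of these compounds alone.

Measured compounds:
- compound 1 `O=C(Nc1ccc2nc(NC(=O)C3CCCCC3)sc2c1)c1ccccc1Cl`: 0.025 ug/mL
- compound 2 `Cc1[nH][n+](C)c(C)c1C(=O)Nc1ccc2nc(NC(=O)C3CCCCC3)sc2c1`: 0.012 ug/mL
- compound 3 `CCCC(=O)Nc1nc2ccc(NC(=O)c3c(Cl)cccc3Cl)cc2s1`: 0.01 ug/mL

In a functional assay on WI-38 VA13 cells (Homo sapiens) for cytotoxicity (on this read-out lower numbers stand for an effect already at smaller amounts and higher numbers for an effect only at larger amounts of compound), compound 3 gives 0.01 ug/mL, the lowest of the three numbers; compound 2 sits within the scatter of it, while compound 1 lies beyond the scatter at the higher end. Within the data shown here, only one single-point step has been measured, a 2.1-fold lower number from compound 1 to compound 2 (0.32 log units; beyond the scatter), and that step alters a different part of the structure from the change considered here, so it gives no direct guidance.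

Compound 4 `COCCOC(=O)Nc1nc2ccc(NC(=O)c3c(Cl)cccc3Cl)cc2s1` differs from compound 3 by 2-methoxyethoxy in place of propyl on a carbonyl carbon. Among the measured compounds shown here, no measured pair changes the group on this carbonyl carbon, so neither direction nor size of the effect can be read from the data. With nothing pointing either way, the working expectation for this assay is a step no larger than the scatter. Compound 4 is therefore estimated at 0.015 ug/mL, with a range of 0.005 ug/mL to 0.05 ug/mL, which means an expected step of a 1.5-fold higher number from compound 3 to compound 4 (0.18 log units; within the scatter).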

Compound 4, half-maximal effective concentration: 0.011 ug/mL
Compound 4: middle estimate off by 1.4-fold (0.13 log units), on the high side; low and high end bracket the measured number.
By their numbers in this assay, from the lowest: compounds 3, 4 and 2 (each within the scatter of the next); then compound 1.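

Among these compounds, on the carbonyl carbon whose other neighbour is the amide-type nitrogen, the change from propyl to 2-methoxyethoxy gives a 1.1-fold higher number from compound 3 to compound 4 (0.04 log units; within the scatter) in this assay, the only direct reading so far at this position. This place therefore tolerates a chain with 2 oxygen atoms and 2 hydrogen-bond acceptors in place of an all-carbon chain, with no change in the read-out beyond the scatter. No evidence at hand bears on this result.

Both groups compared here are open chains without a ring or net charge, so an amine, a carboxylic acid or a longer alkyl chain on this carbonyl carbon remains untested in the compounds shown. Also open, as far as these compounds go, is whether 2-methoxyethoxy would read the same way on the core of compound 1 or compound 2.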